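Two rings tried on one saturated carbon, a third expected

This account rests on a few compounds, and the source may have more. Where it says the series, first, only, none or still open, it means among the compounds named here.

Measured so far in a functional assay on HEK293 cells for agonist activity at D(4) dopamine receptor (Homo sapiens), read by FLIPR; on this read-out higher numbers stand for larger maximal responses and lower numbers for smaller maximal responses:
Compound 1, `Cc1cccc(C(=O)NCN2CCC(c3nccs3)CC2)c1`, gives 71%.
Compound 2, `Cc1cccc(C(=O)NCN2CCC(c3cccc[n+]3[O-])CC2)c1`, gives 77%.

Among the measured compounds shown here, compound 2 shows the larger of the two numbers, yet its only measured neighbour is compound 1, and the step of a number 6 percentage points higher from compound 1 to compound 2 (within the scatter) does not leave the scatter. Compound 3, `COc1ccccc1C1CCN(CNC(=O)c2cccc(C)c2)CC1`, changes the group on the same saturated ring carbon once more: a group of 8 heavy atoms (7 carbon, 1 oxygen; one six-membered aromatic ring of carbon only) in place of a group of 7 heavy atoms (5 carbon, 1 nitrogen, 1 oxygen; one six-membered aromatic ring with 1 hetero atom), on a saturated ring carbon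

For the measured compounds named here, the one measured step that bears on this change is the earlier swap on this carbon, a number 6 percentage points higher from compound 1 to compound 2 (within the scatter), which stayed within the scatter. With nothing else measured here, no step beyond the scatter is expected, so the estimated change is a number 4 percentage points lower from compound 2 to compound 3 (within the scatter). Compound 3 is therefore expected to give about 73% in this assay, with a range from 55% to 90%.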

Compound 3, largest response reached (reported as efficacy), in percent of the reference or control that the assay uses: 55%
Estimate against measurement, compound 3: 18 percentage points above; the measured number falls inside the stated range.
By their numbers in this assay, from the lowest: compound 3; then compounds 1 and 2 (each within the scatter of the next).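

The group on this saturated ring carbon can change the maximal response in this assay: replacing it gives a number 22 percentage points lower from compound 2 to compound 3 (beyond the scatter) and also a number 16 percentage points lower from compound 1 to compound 3 (beyond the scatter), whereas the earlier swap between the two hetero-atom rings stayed within the scatter. Among these three compounds, the 2-methoxyphenyl group, with its aromatic ring of carbon only, stands apart from the two groups whose aromatic rings carry a hetero atom, although each step changes more than one feature at once. Nothing shown here explains why the response falls.

On these data alone, it remains open whether the ring of carbon only or the methoxy group goes with the lower number, and plain phenyl would help separate the two. Also open, as far as these compounds go, is how a group of another kind on this carbon, such as an aminomethyl group or a carboxylic acid, would compare.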